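Swapping a Methoxycarbonyl for a Benzyl on the Ring Nitrogen

The source may report more compounds than this note shows. Statements on the series, on what has been measured and on what is new or still open speak of the compounds shown alone.

Measured compounds:
compound 1 `COC(=O)Nc1c(C)nc2c(OCc3ccccc3)cccn12` gives 0%
compound 2 `Cc1nc2c(OCc3ccccc3)cccn2c1NC(=O)OCc1ccccc1` gives 8%

Of the compounds shown here, two have so far been tested in a functional assay on the whole organism with Rattus norvegicus as the target, at a dose of 40 mg/kg by the intraperitoneal route; a higher number here means more inhibition at the dose given (going by the name of the read-out), a lower number less inhibition. Compound 1 gives 0%, the lower of the two numbers, and compound 2 gives 8%, which is the nearest to it; the step of a number 8 percentage points higher from compound 1 to compound 2 (within the scatter) lies within the scatter, so the two cannot be told apart. That step changes the compound by phenyl in place of hydrogen on a saturated chain carbon bound to an oxygen next to a carbonyl group, the carbonyl itself staying in place.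

Compound 3 `Cc1nc2c(OCc3ccccc3)cccn2c1NCc1ccccc1` has not yet been measured. It differs from compound 1 by benzyl in place of methoxycarbonyl on a nitrogen on an aromatic ring. Among the compounds with values here, the carbonyl that both measured compounds share is thereby removed, a change of another kind than the one measured step, so that step gives no direct guide. With both known numbers close to no inhibition, the expectation for compound 3 is a small number, and the step of a number 10 percentage points higher from compound 1 to compound 3 (within the scatter) is expected to stay close to the scatter. Compound 3 is estimated at 10%, within a range from 0% to 40%.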

Compound 3, a percentage reported as inhibition, in the whole organism at one dose (the size of the read-out at that dose, not a potency): 48%
Beside the measured number, compound 3's estimate is 38 percentage points below it; measured number outside the range, above it.
By their numbers in this assay, from the lowest: compounds 1 and 2 (each within the scatter of the next); then compound 3.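

In this assay, within the data shown here, the group on this nitrogen on an aromatic ring clearly matters: putting benzyl in place of methoxycarbonyl gives a number 48 percentage points higher from compound 1 to compound 3 (beyond the scatter), a large step, whereas the only earlier step, a number 8 percentage points higher from compound 1 to compound 2 (within the scatter), could not be told from the scatter. That earlier step added a phenyl while keeping the carbonyl, so adding an aromatic ring with the carbonyl in place was not enough to give a clear rise, and the clear rise appears only in the compound that has both the ring and no carbonyl. The data offer no measurement that explains why this change has such an effect.

Still open, on these data alone, is whether losing the carbonyl would be enough on its own or whether the phenyl ring is needed as well, a question that a free amine or a simple methyl group on this nitrogen would bear on. Also open, as far as these compounds go, is how the number would respond to a longer chain between the nitrogen and the phenyl ring, as in phenethyl, or to a chlorine on the ring of the benzyl group.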